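Swapping one fused ring for another in a calpain-1 series

The compounds below may be only part of what the source reports. "The series", "measured", "known", "first", "only" and "open" are said of these compounds alone.

Four related compounds share a core in which a double-bonded chain carbon carries an amine nitrogen and a fused two-ring group. Compound 1 `O=C1/C(=C(\NCc2ccccc2)c2cc3cccnc3[nH]2)N=CN1Cc1ccccc1` and compound 2 `O=C1/C(=C(\NCc2ccccc2)c2cc3ccccc3[nH]2)N=CN1Cc1ccccc1` carry benzyl groups on the amine and on the ring nitrogen, while compound 3 `O=C1/C(=C(\NC2CCCCC2)c2cc3cccnc3[nH]2)N=CN1C1CCCCC1` and compound 4 `O=C1/C(=C(\NC2CCCCC2)c2cc3ccccc3[nH]2)N=CN1C1CCCCC1` carry cyclohexyl groups there; the difference between the two cores is not broken down here.

In an assay on isolated protein for inhibition of Calpain-1 catalytic subunit (Homo sapiens), read by fluorescence, with a stated time of 60 min, tested at 1 uM (on this read-out higher numbers stand for more inhibition at the one concentration tested (going by the name of the read-out) and lower numbers for less inhibition), compound 1 gives 11.7% and compound 2 gives 28.2%. The change between them is a group of 9 heavy atoms (8 carbon, 1 nitrogen; one five-membered aromatic ring with 1 hetero atom, one six-membered aromatic ring of carbon only) in place of a group of 9 heavy atoms (7 carbon, 2 nitrogen; one five-membered aromatic ring with 1 hetero atom, one six-membered aromatic ring with 1 hetero atom), on a double-bonded chain carbon bound to an amine nitrogen and a double-bonded ring carbon, and it produced a number 16.5 percentage points higher from compound 1 to compound 2 (beyond the scatter). In this assay compound 3 gives 4.5%.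

Compound 4 differs from compound 3 by a group of 9 heavy atoms (8 carbon, 1 nitrogen; one five-membered aromatic ring with 1 hetero atom, one six-membered aromatic ring of carbon only) in place of a group of 9 heavy atoms (7 carbon, 2 nitrogen; one five-membered aromatic ring with 1 hetero atom, one six-membered aromatic ring with 1 hetero atom), on a double-bonded chain carbon bound to an amine nitrogen and a double-bonded ring carbon, the same change. Compound 4 is expected to show a number 15.5 percentage points higher from compound 3 to compound 4 (beyond the scatter), a step of about the same size as the earlier one, because the identical change gave a number 16.5 percentage points higher from compound 1 to compound 2 (beyond the scatter). This expectation rests on a single measured pair, so it is held loosely. Compound 4 is therefore estimated at 20%, with a range from 8% to 33%.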

Compound 4, a percentage reported as inhibition, at one concentration (the size of the read-out at that concentration, not a potency): 9%
Compound 4: the middle estimate sits 11 percentage points above what was measured, within the range that was stated.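

In this assay, replacing the two-nitrogen fused group with 1H-indol-2-yl on the cyclohexyl-bearing core gave a number 4.5 percentage points higher from compound 3 to compound 4 (within the scatter), so on this core the swap cannot be told apart from no change at all. Set beside the benzyl-bearing pair, the two steps cannot be told apart from each other either: the same change on two cores in this assay, a number 16.5 percentage points higher (beyond the scatter) from compound 1 to compound 2 and a number 4.5 percentage points higher (within the scatter) from compound 3 to compound 4, 12 percentage points apart, within the scatter of two such steps. The data therefore fit a change that carries from one core to the other, but they do not establish it, as the step stands clear of the scatter on the benzyl-bearing core only and each core offers just a single pair.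

The compounds shown leave open whether the swap would behave the same way with other groups on the amine and the ring nitrogen, such as a methyl group or a longer chain bearing an amine. They also leave open how these compounds compare at concentrations other than the single one used in this assay.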